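The source may hold more compounds than are shown below. What is called first, only, known or untested is meant among the compounds shown, and "the series" means these compounds.

Measured compounds:
- compound 1, `CCCC(=O)c1ccc(OCCCCOc2cc(C(=O)O)ccc2OC)c(C)c1O`: 496 nM
- compound 2, `Cc1c(OCCCCOc2cccc(C(=O)O)c2)ccc(C(=O)CC(C)C)c1C`: "not determined" (no result reported)

In an assay on HEK293 cells for positive allosteric modulation of metabotropic glutamate receptor 3 (Rattus norvegicus), read by thallium flux, with a stated time of 2.5 min (a higher number here means that more compound is needed for the effect, a lower number that less compound is needed), compound 1 gives 496 nM. Among the compounds with values here, compound 2 gives "not determined" (no result reported) in this assay, so compound 1 stands as the only compound with a number, and nothing can be set beside it for comparison.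

Compound 3, `COc1ccc(C(=O)O)cc1OCCCCOc1ccc(C(=O)CC(C)C)c(O)c1C`, has not been measured in this assay. It differs from compound 1 in one place: methyl in place of hydrogen on a saturated chain carbon bound to two saturated chain carbons. Within the data shown here, no step between two measured compounds is known, so there is no measured guide to how a change of this kind moves the readout. With only the added methyl on the chain to go on, the expectation is a step from compound 1 to compound 3 of about a 1.1-fold lower number from compound 1 to compound 3 (0.04 log units; within the scatter), a shift that is expected to sit within the usual scatter, in no clear direction. Compound 3 is therefore estimated to give 450 nM in this assay, with a range from 150 nM to 1400 nM.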

Compound 3, half-maximal effective concentration: 737 nM
Compound 3: middle estimate off by 1.6-fold (0.21 log units), on the low side; the measured number falls inside the stated range.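

Placing a methyl on a saturated chain carbon bound to two saturated chain carbons, which turns propylcarbonyl into isobutylcarbonyl, gives a 1.5-fold higher number from compound 1 to compound 3 (0.17 log units; within the scatter) in this assay. This first measured step at this position shows that the branched chain still gives a measurable effect, and that compound 1 and compound 3 cannot be told apart within the usual scatter. Nothing available explains this result.

Within the data shown here, only this one small change has been read at this chain carbon, so a single methyl says little about how larger changes would behave. Open questions include whether an amine or a hydroxyl on that carbon, or a longer chain in place of isobutylcarbonyl, would shift the number beyond the scatter.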